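The source may hold more compounds than are shown below. What is called first, only, known or untested is meant among the compounds shown, and "the series" means these compounds.

In a functional assay on HT-1080 cells (Homo sapiens) for cytotoxicity, read by MTT assay, with a stated time of 72 h (a higher number here means a weaker inhibitor, a lower number a stronger inhibitor), compound 1 `COc1cccc(/C=C2\CCC/C(=C\c3ccc(Cl)cc3)C2=O)c1OC` gives 11100 nM and compound 2 `COc1ccc(/C=C2\CCC/C(=C\c3cccc(OC)c3OC)C2=O)cc1` gives 16300 nM on the shared core. Compound 3 `COc1cccc(/C=C2\CCC/C(=C\c3ccc(O)c(Cl)c3)C2=O)c1OC` reads 14300 nM and sits level with the other two, its steps being a 1.3-fold higher number from compound 1 to compound 3 (0.11 log units; within the scatter) and a 1.1-fold lower number from compound 2 to compound 3 (0.06 log units; within the scatter) so that the three numbers cannot be ranked.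

Compound 4 `COc1cc(/C=C2\CCC/C(=C\c3cccc(OC)c3OC)C2=O)ccc1O` has not yet been measured. It departs from compound 3 by methoxy in place of chloro on an aromatic carbon with methoxy in place of chloro on an aromatic carbon, turning 3-chloro-4-hydroxyphenyl into 4-hydroxy-3-methoxyphenyl. Going by the values given here, the closest precedent is the same exchange in a 1.5-fold higher number from compound 1 to compound 2 (0.17 log units; within the scatter) but there on a ring that carries no hydroxy group, so it reads across only in part. Among the compounds with values here, no measured compound carries the 4-hydroxy-3-methoxyphenyl group. The step of a 1.1-fold lower number from compound 2 to compound 3 (0.06 log units; within the scatter) also links a methoxy-bearing ring to the 3-chloro-4-hydroxyphenyl ring and likewise shows nothing beyond the scatter. No change beyond the scatter is therefore expected in this assay and no direction can be called. The expected step is a 1.0-fold lower number from compound 3 to compound 4 (0.01 log units; within the scatter) on this estimate. For compound 4 the estimated value is 14000 nM with 6500 nM to 28000 nM as the expected range.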

Compound 4, half-maximal inhibitory concentration: 5900 nM
Compound 4: the middle estimate sits 2.4-fold (0.38 log units) above what was measured; the measured number lies below the stated range.
By their numbers in this assay, from the lowest: compounds 4, 1, 3 and 2 (each within the scatter of the next, the first and the last beyond it).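

In this assay, going by these compounds alone, methoxy in place of chloro on an aromatic carbon ortho to a hydroxy group gives a 2.4-fold lower number from compound 3 to compound 4 (0.38 log units; beyond the scatter) and so moves the number beyond the scatter, which no step among compounds 1, 2 and 3 did. Compound 4 also separates from compound 2 by a 2.8-fold lower number from compound 2 to compound 4 (0.44 log units; beyond the scatter) but not from compound 1 by a 1.9-fold lower number from compound 1 to compound 4 (0.27 log units; within the scatter) and so cannot be called the strongest of the four. The exchange therefore does not carry over unchanged between the two cores, and its outcome at this position depends on the rest of the molecule: the same change on two cores in this assay, a 1.5-fold higher number (0.17 log units; within the scatter) from compound 1 to compound 2 and a 2.4-fold lower number (0.38 log units; beyond the scatter) from compound 3 to compound 4, 3.6-fold (0.55 log units) apart, beyond the scatter of two such steps.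

Within the data shown here, only one pair shows this exchange with a hydroxy group on the changed ring, so it remains open whether the hydroxy group is needed for the lower number or whether the second aryl ring also contributes. From the compounds shown here alone, it is also open whether the step continues with a longer chain such as ethoxy or with an amine at the same place, and whether it holds in any cell line other than this one.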